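A Benzyl Swap on a Core That Spares Cells

The source may report more compounds than this note shows. Statements on the series, on what has been measured and on what is new or still open speak of the compounds shown alone.

Compound 2, `CN1C(=S)[C@@H](NC(=O)c2nc(Cc3ccccc3)n(CCCC(F)(F)F)n2)COc2ccccc21`, was tested in a toxicity assay on HT-29 cells (Homo sapiens) for cytotoxicity; on this read-out lower numbers stand for higher toxicity in this test and higher numbers for lower toxicity in this test. In this assay compound 2 gives > 100000 nM, which is a limit of the assay and not a measured number. Its two measured relatives share the same fate. Compound 1, `CCCCn1nc(C(=O)N[C@H]2COc3ccccc3N(C)C2=S)nc1Cc1ccccc1`, gives > 100000 nM in this assay, again a limit. Compound 3, `CN1C(=S)[C@@H](NC(=O)c2nc(Cc3ccccc3)n(C3CCNC3)n2)COc2ccccc21`, gives > 100000 nM in this assay, also a limit. The changes between these three therefore yield no readable sizes: from compound 1 to compound 2 the step is a step that the two limits leave unreadable from compound 1 to compound 2, from compound 1 to compound 3 it is a step that the two limits leave unreadable from compound 1 to compound 3, and from compound 2 to compound 3 it is a step that the two limits leave unreadable from compound 2 to compound 3. What unites them is the limit of > 100000 nM in this assay, at which 3 of the 3 values shown sit.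

Compound 4, `CN1C(=S)[C@@H](NC(=O)c2nc(Cc3ccccc3)n(Cc3ccccc3)n2)COc2ccccc21`, is the unmeasured relative. It differs from compound 2 in one place: phenyl in place of 3,3,3-trifluoropropyl on a saturated chain carbon bound to an aromatic nitrogen. Among the measured compounds shown here, no measured step touches a phenyl on that chain carbon, so the only guide is that every change so far around the aromatic nitrogen left the compounds at the limit. Compound 4 is therefore expected to give 150000 nM in this assay, within a range of 50000 nM to 500000 nM. For compound 4 this estimate means an expected step that the limit leaves unreadable from compound 2 to compound 4, most likely reported as a limit once more.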

Compound 4, half-maximal cytotoxic concentration: > 100000 nM
Compound 4: only a limit was reported; the forecaster's own chance of this, stated with the estimate: 85%; the middle value is on the limit's open side.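

In this assay compound 4 gives > 100000 nM, which is again a limit and not a measured number. Its steps from compound 1, compound 2 and compound 3 therefore cannot be read, as all four compounds share one result: the limit of > 100000 nM in this assay, at which 4 of the 4 values shown sit.

The compounds shown leave open whether these four differ at all in toxicity to these cells.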